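Adding trifluoromethoxy to an already stable compound

The source may hold more compounds than are shown below. What is called first, only, known or untested is meant among the compounds shown, and "the series" means these compounds.

Measured in an ADME assay on microsomes from liver (Canis lupus familiaris) for metabolic stability, with a stated time of 10 min; on this read-out lower numbers stand for a less stable compound and higher numbers for a more stable compound:
- compound 1 `Fc1ccccc1-c1ccc2[nH]c(C3=NOC4(CCCCC4)C3)nc2c1`: 47%
- compound 2 `FC(F)(F)Oc1ccccc1-c1ccc2[nH]c(C3=NOC4(CCCCC4)C3)nc2c1`: 81%
- compound 3 `Fc1ccccc1-c1cc(C(F)(F)F)c2[nH]c(C3=NOC4(CCCCC4)C3)nc2c1`: 82%

In this assay, compound 3 lies within the scatter of compound 2, and both lie well beyond the scatter from compound 1. Compound 4 `FC(F)(F)Oc1ccccc1-c1cc(C(F)(F)F)c2[nH]c(C3=NOC4(CCCCC4)C3)nc2c1` differs from compound 3 by trifluoromethoxy in place of fluoro on an aromatic carbon, with trifluoromethoxy in place of fluoro on an aromatic carbon. That same replacement has been measured once, as a number 34 percentage points higher from compound 1 to compound 2 (beyond the scatter), a large step. The other change carried by compound 4, trifluoromethyl in place of hydrogen, gave a number 35 percentage points higher from compound 1 to compound 3 (beyond the scatter), also large. Both steps started from the much lower value of compound 1, 47%. Compound 3 starts at 82%, which leaves too little room in the amount remaining for a repeat of that full step. A further rise is expected, but a small one. The estimate means a number 9 percentage points higher from compound 3 to compound 4 (within the scatter), an expected step far smaller than either measured one. Compound 4 is expected at about 91%, with an estimated range of 80% to 100%.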

Compound 4, percent of the compound remaining: 50%
Estimate against measurement, compound 4: 41 percentage points above, and the stated range ends above it.
By their numbers in this assay, from the lowest: compounds 1 and 4 (each within the scatter of the next); then compounds 2 and 3 (each within the scatter of the next).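

In this assay the replacement of fluoro by trifluoromethoxy, on an aromatic carbon ortho to a large group, proves to have no fixed direction, since on the core carrying trifluoromethyl it gives a number 32 percentage points lower from compound 3 to compound 4 (beyond the scatter): the same change on two cores in this assay, a number 34 percentage points higher (beyond the scatter) from compound 1 to compound 2 and a number 32 percentage points lower (beyond the scatter) from compound 3 to compound 4, 66 percentage points apart, beyond the scatter of two such steps.
Trifluoromethyl in place of hydrogen reverses in the same way, giving a number 31 percentage points lower from compound 2 to compound 4 (beyond the scatter): the same change on two cores in this assay, a number 35 percentage points higher (beyond the scatter) from compound 1 to compound 3 and a number 31 percentage points lower (beyond the scatter) from compound 2 to compound 4, 66 percentage points apart, beyond the scatter of two such steps.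
Each change raises the number when made alone, yet the two together do not add up, and compound 4, which carries both, stands within the scatter of compound 1, which carries neither.

The compounds shown do not tell why the two groups fail to combine, or whether this belongs to trifluoromethoxy in particular or would hold for other groups at this place. A methoxy or a chloro in place of trifluoromethoxy, on the core carrying trifluoromethyl, would separate these readings.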